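Changing the Aryl Group on the Core of Compound 1

The source may hold more compounds than are shown below. What is called first, only, known or untested is meant among the compounds shown, and "the series" means these compounds.

Compound 1, `CC(C)OC(=O)N1CCC(Oc2ncnc3c2CCN3c2ccc(S(C)(=O)=O)cc2F)CC1`, gives 50.1 nM in a functional assay on CHO-K1 cells for agonist activity at Glucose-dependent insulinotropic receptor (Homo sapiens), read by a luciferase reporter, with a stated time of 5 h; on this read-out lower numbers stand for an effect already at smaller amounts and higher numbers for an effect only at larger amounts of compound.
Compound 2, `CCSC(=O)N1CCC(Oc2ncnc3c2CCN3c2ccc(S(C)(=O)=O)cc2F)CC1`, gives 31.6 nM.
Compound 3, `CC(C)c1noc(N2CCC(Oc3ncnc4c3CCN4c3ccc(S(C)(=O)=O)cc3F)CC2)n1`, gives 79.4 nM.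

Among these three numbers compound 1 stands second highest. Its nearest neighbour is compound 3, with a 1.6-fold higher number from compound 1 to compound 3 (0.20 log units; within the scatter), and its furthest is compound 2, with a 1.6-fold lower number from compound 1 to compound 2 (0.20 log units; within the scatter); both of these steps lie within the scatter. Among the measured compounds shown here, the only step beyond the scatter is a 2.5-fold higher number from compound 2 to compound 3 (0.40 log units; beyond the scatter), and it is modest.

Compound 4, `CSc1ccc(N2CCc3c(OC4CCN(C(=O)OC(C)C)CC4)ncnc32)cc1F`, differs from compound 1 in a single place: a group of 9 heavy atoms (7 carbon, 1 fluorine, 1 sulfur; one six-membered aromatic ring of carbon only) in place of a group of 11 heavy atoms (7 carbon, 2 oxygen, 1 fluorine, 1 sulfur; one six-membered aromatic ring of carbon only), on a nitrogen on an aromatic ring in a ring. For the measured compounds named here, all three measured steps concern the group on the amine nitrogen in a ring, so none of them bears on a change to the 2-fluoro-4-(methylsulfonyl)phenyl group; no measured step touches the nitrogen on an aromatic ring in a ring of the five-membered non-aromatic ring at all. The expectation for compound 4 therefore rests only on the narrow spread of the three measured values, and a step toward a higher number, a 2.0-fold higher number from compound 1 to compound 4 (0.30 log units; within the scatter), is estimated with wide uncertainty. The estimated value for compound 4 is 100 nM, with a range from 25 nM to 400 nM.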

Compound 4, half-maximal effective concentration: 398 nM
Compound 4: middle estimate off by 4.0-fold (0.60 log units), on the low side; low and high end bracket the measured number.
By their numbers in this assay, from the lowest: compounds 2, 1 and 3 (each within the scatter of the next, the first and the last beyond it); then compound 4.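

At the nitrogen on an aromatic ring in a ring, the change of aryl group gives a 7.9-fold higher number from compound 1 to compound 4 (0.90 log units; beyond the scatter) in this assay, a larger step than any seen at the amine nitrogen in a ring, where the largest is a 2.5-fold higher number from compound 2 to compound 3 (0.40 log units; beyond the scatter). Among these four compounds, then, the read-out responds more strongly to the group at this position than to the group on the amine nitrogen, and the 2-fluoro-4-(methylsulfonyl)phenyl group gives the lower number of the two aryl groups compared here; the entering group has neither of the two oxygens of the group it replaces, and the structures also show the fluorine on a different carbon of the aromatic ring, so this one step covers both differences together. Nothing available here explains why the number rises.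

The compounds shown leave open how much of the step belongs to the lost oxygens and how much to the moved fluorine. They also leave open how other groups would behave on that aromatic ring, such as a nitrile, a methylsulfinyl group or a carboxylic acid, and whether the step would be the same size with the ethylsulfanyl carbonyl group of compound 2 on the amine nitrogen.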